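The compounds below may be only part of what the source reports. "The series", "measured", "known", "first", "only" and "open" are said of these compounds alone.

Measured in a functional assay on HEK293 cells for antagonist activity at Voltage-dependent L-type calcium channel subunit alpha-1D (Rattus norvegicus), read by FLIPR; a lower number here means a stronger inhibitor, a higher number a weaker inhibitor:
Compound 1, `C=CCOC(=O)C1=C(C)NC(C)=C(C(=O)OC)C1c1ccccc1[N+](=O)[O-]`, gives 10 nM
Compound 2, `CCCCCOC(=O)C1=C(C)NC(C)=C(C(=O)OCC)C1c1cccc([N+](=O)[O-])c1`, gives 130 nM
Compound 3, `COC(=O)C1=C(C)NC(C)=C(C(=O)OC2C=CCCC2)C1c1cccc([N+](=O)[O-])c1`, gives 10 nM

Compound 3 is level with compound 1 at the digits shown, the two together giving the lowest numbers of the three; compound 2 gives a higher number, a gap beyond the scatter. Compound 4, `COC(=O)C1=C(C)NC(C)=C(C(=O)OCCC(C)c2ccccc2)C1c1cccc([N+](=O)[O-])c1`, differs from compound 3 by 3-phenylbutyl in place of cyclohex-2-en-1-yl on an oxygen next to a carbonyl group. Among the compounds with values here, no step between two measured compounds matches this change, so the size of its effect is not known. Compound 4 is expected to give a slightly higher number than compound 3, a step of a 2.5-fold higher number from compound 3 to compound 4 (0.40 log units; beyond the scatter), modest but possibly beyond the scatter. The estimated value for compound 4 is 25 nM, within the range 8 nM to 80 nM.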

Compound 4, half-maximal inhibitory concentration: 11 nM
Compound 4: the middle estimate sits 2.3-fold (0.36 log units) above what was measured; the range from low to high includes it.
By their numbers in this assay, from the lowest: compounds 1, 3 and 4 (each within the scatter of the next); then compound 2.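

At this place, on an oxygen next to a carbonyl group, 3-phenylbutyl in place of cyclohex-2-en-1-yl gives a 1.1-fold higher number from compound 3 to compound 4 (0.04 log units; within the scatter) in this assay. The position therefore accommodates a group of 10 heavy atoms with a six-membered aromatic ring as well as one of 6 heavy atoms with a non-aromatic ring, the two numbers standing level. Nothing at hand gives a reason for this.

Going by these compounds, whether an amine or a carboxylic acid carried on this oxygen would stay level remains open. So does the outcome for a longer chain.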